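Removing a Nitro Group from an Anticancer Lead

This account rests on a few compounds, and the source may have more. Where it says the series, first, only, none or still open, it means among the compounds named here.

Of the compounds shown here, three sharing one core have been tested in a functional assay on A2780 cells (Homo sapiens) for antiproliferative activity, read by MTT assay, with a stated time of 3 days; a lower number here means a stronger inhibitor, a higher number a weaker inhibitor. Compound 1 `CC/C=C/COC1(c2ccc(Cl)cc2)SC=C(C)n2c1noc2=O` gives 55000 nM. For the measured compounds named here, compound 2 `COC1(c2ccc(Cl)cc2)SC=C(C)n2c1noc2=O` gives 166000 nM, and the step of a 3.0-fold higher number from compound 1 to compound 2 (0.48 log units; beyond the scatter) is the only change measured on its own. Compound 3 `CC1=CSC(O)(c2cccc([N+](=O)[O-])c2)c2noc(=O)n21` gives 159000 nM; among the three numbers this is the second highest, lying within the scatter of compound 2 but beyond it from compound 1.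

Compound 4 `CC1=CSC(O)(c2ccccc2)c2noc(=O)n21` has not yet been measured in this assay. It differs from compound 3 in a single way: hydrogen in place of nitro on an aromatic carbon. Going by the values given here, no measured step touches this part of the molecule, since the one step available concerns a chain on an oxygen at the saturated carbon and not the six-membered aromatic ring of carbon only. There is therefore no ground for expecting a shift beyond the scatter in either direction. Compound 4 is estimated at 150000 nM, with a range from 60000 nM to 400000 nM. The estimated step of a 1.1-fold lower number from compound 3 to compound 4 (0.03 log units; within the scatter) is thus expected to stay within the usual scatter.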

Compound 4, half-maximal inhibitory concentration: > 100000 nM
Compound 4 was reported as a limit; the forecaster's own chance of this, stated with the estimate: 20%; the middle value lies beyond the limit too.
By their numbers in this assay, from the lowest: compound 1; then compounds 3 and 2 (each within the scatter of the next).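

In this assay compound 4 gives > 100000 nM, which is a limit of the assay and not a number. The step from compound 3 to compound 4 cannot be read from it. The compounds shown leave open whether hydrogen in place of nitro shifts the number at all, and in which direction.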